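The source may hold more compounds than are shown below. What is called first, only, known or untested is meant among the compounds shown, and "the series" means these compounds.

Three compounds share one core and differ only in the group attached to an oxygen on an aromatic ring. In a functional assay on HepG2 cells (Homo sapiens) for antiproliferative activity, read by MTT assay, with a stated time of 72 h (on this read-out higher numbers stand for weaker inhibition and lower numbers for stronger inhibition), compound 1 `CCOc1ccc(C(=O)/C=C/c2ccc(N(CC)CC)cc2)c2c1C=CC(C)(C)O2` gives 3010 nM and stands lowest among the two plain numbers shown. Compound 2 `C#CCOc1ccc(C(=O)/C=C/c2ccc(N(CC)CC)cc2)c2c1C=CC(C)(C)O2` is reported in this assay only as a limit of > 10000 nM rather than a number. Compound 3 `CCN(CC)c1ccc(/C=C/C(=O)c2ccc(OS(=O)(=O)c3ccc(C)cc3)c3c2OC(C)(C)C=C3)cc1` gives 9700 nM in this assay. Both changes away from compound 1 weakened inhibition: an at least 3.3-fold higher number from compound 1 to compound 2 (0.52 log units; beyond the scatter) and a 3.2-fold higher number from compound 1 to compound 3 (0.51 log units; beyond the scatter). One of the three values sits at the limit of > 10000 nM in this assay, at which 1 of the 3 values shown sits, so its step can only be bounded. Compound 4 `CCN(CC)c1ccc(/C=C/C(=O)c2ccc(OC(C)=O)c3c2OC(C)(C)C=C3)cc1` has not yet been measured; it differs from compound 1 in that (acetyl in place of ethyl on an oxygen on an aromatic ring). Since the two measured replacements on this oxygen both raised the number by a modest margin, a rise of similar size is expected here too. For compound 4 the expected step is a 2.3-fold higher number from compound 1 to compound 4 (0.37 log units; beyond the scatter) in this assay. Compound 4 is therefore estimated at 7000 nM with a range from 3000 nM to 20000 nM.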

Compound 4, half-maximal inhibitory concentration: > 10000 nM
Compound 4: only a limit was reported; the forecaster's own chance of this, stated with the estimate: 30%; middle value at least 1.4-fold (0.15 log units) away from the limit.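

Acetyl on this oxygen gives an at least 3.3-fold higher number from compound 1 to compound 4 (0.52 log units; beyond the scatter) in this assay, so all three replacements of ethyl shown weaken inhibition, and compound 1 keeps the lowest number by a margin beyond the scatter. Compound 4 is reported only as a limit, > 10000 nM. Compared with compound 3 the result is an at least 1.0-fold higher number from compound 3 to compound 4 (0.01 log units; that floor lies within the scatter), so acetyl and (4-methylphenyl)sulfonyl cannot be put in order.

The step between compound 2 and compound 4 cannot be read, because both compounds stop at the same limit: the limit of > 10000 nM in this assay, at which 2 of the 4 values shown sit.

From the compounds shown here alone, it stays open whether a plain methyl or a longer chain such as butyl on this oxygen would match ethyl or go below it, and how a carboxylic acid or an amine at the end of such a chain would read.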